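The source may hold more compounds than are shown below. What is called first, only, known or untested is meant among the compounds shown, and "the series" means these compounds.

Measured so far:
- compound 1 `CCOC(=O)C1=C(C)N/C(=N\C#N)NC1c1cccs1`: 26%
- compound 2 `CC1=C(C(=O)OC(C)C)C(c2ccccc2)NC(=O)N1`: 2%

Both compounds were run in an assay on cells for displacement of a labelled ligand from adenosine receptor A1 (Homo sapiens), with a stated time of 60 min, tested at 1 uM; on this read-out higher numbers stand for more inhibition at the one concentration tested (going by the name of the read-out) and lower numbers for less inhibition. Compound 1 gives 26%, the higher of the two numbers, and compound 2 gives 2%; the gap between them is beyond the usual scatter, so compound 1 stands clearly above compound 2 on this read-out. The two compounds differ in more than one place, so nothing is made of which part of the change carries that gap.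

The next compound in the series is compound 3 `CCOC(=O)C1=C(C)N/C(=N\C#N)NC1C1CCCC1`, not yet measured in this assay. It keeps the core of compound 1 and differs only in one group: cyclopentyl in place of thiophen-2-yl on a saturated ring carbon. The ring that leaves and the ring that enters are of the same size, so the step is expected to be small, at most a slight drop, and not clearly beyond the scatter.

The expectation for compound 3 in this assay is 22%, within 6% to 42%. That estimate means an expected step of a number 4 percentage points lower from compound 1 to compound 3 (within the scatter), a shift that would sit inside the scatter of the measurement.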

Compound 3, a percentage reported as inhibition, at one concentration (the size of the read-out at that concentration, not a potency): 11%
Estimate against measurement, compound 3: 11 percentage points above; low and high end bracket the measured number.
By their numbers in this assay, from the lowest: compounds 2 and 3 (each within the scatter of the next); then compound 1.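

In this assay, among the compounds shown here, the saturated ring carbon next to the ring nitrogen gives the first single-place comparison: cyclopentyl in place of thiophen-2-yl gives a number 15 percentage points lower from compound 1 to compound 3 (beyond the scatter). This position therefore distinguishes between two five-membered rings of 5 heavy atoms each, and thiophen-2-yl, the aromatic ring with 1 hetero atom, goes with the higher number. This single pair changes aromaticity, the sulfur atom and the hydrogen-bond acceptor count together, so it cannot assign the step to any one of them, and no measurement at hand bears on a cause.

The compounds shown leave open whether the higher number follows the aromatic ring or the sulfur atom, and a furyl group on the core of compound 1 would bear on that question. They also leave open whether this carbon accepts an open chain such as hexyl, or an amine carried on the ring, at a level that stands apart from compound 3 in this assay.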